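The source may report more compounds than this note shows. Statements on the series, on what has been measured and on what is new or still open speak of the compounds shown alone.

Of the compounds shown here, three built on one shared core have been tested in an ADME assay on cells (Macrophage, Mus musculus) for cytotoxicity, read by resazurin assay, with a stated time of 3 days; a higher number here means a weaker inhibitor, a lower number a stronger inhibitor. Compound 1 `O=C(Nc1cccc(C(F)(F)F)c1)c1cc(Cl)ccc1O` gives 5900 nM in this assay. Compound 2 `O=C(Nc1cccc(F)c1)c1cc(Cl)ccc1O` gives 15000 nM, and compound 3 `O=C(Nc1ccc(F)c(C(F)(F)F)c1)c1cc(Cl)ccc1O` gives 5300 nM. The step from compound 1 to compound 2 is a 2.5-fold higher number from compound 1 to compound 2 (0.41 log units; beyond the scatter); the change is fluoro in place of trifluoromethyl on an aromatic carbon. The step from compound 1 to compound 3 is a 1.1-fold lower number from compound 1 to compound 3 (0.05 log units; within the scatter); the change is fluoro in place of hydrogen on an aromatic carbon.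

Compound 4 `O=C(Nc1cc(F)cc(F)c1)c1cc(Cl)ccc1O` has not yet been measured in this assay. It differs from compound 2 by fluoro in place of hydrogen on an aromatic carbon. Among the measured compounds shown here, this is the same kind of change as the one from compound 1 to compound 3, but not the same: in compound 3 the entering fluoro sits ortho to a trifluoromethyl group and para to a large group, while in compound 4 it sits meta to a fluoro group and meta to a large group. The cores of compound 2 and compound 4 also differ from the core of compound 1, as told by fluoro in place of trifluoromethyl on an aromatic carbon.

The step from compound 2 to compound 4 is expected to be a 1.2-fold lower number from compound 2 to compound 4 (0.06 log units; within the scatter), a small step, because the earlier step of this kind was a 1.1-fold lower number from compound 1 to compound 3 (0.05 log units; within the scatter). Compound 4 is therefore estimated at 13000 nM in this assay.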

Compound 4, half-maximal inhibitory concentration: 6100 nM
For compound 4 the middle estimate is 2.1-fold (0.33 log units) above the measured one; the measured number falls inside the stated range.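

In this assay, putting fluoro in place of hydrogen on an aromatic carbon gives a 2.5-fold lower number from compound 2 to compound 4 (0.39 log units; beyond the scatter), with the entering fluoro meta to a fluoro group and meta to a large group. Set beside the earlier case of this change, the two steps look different at first sight, yet the gap between them is no larger than the scatter of two such steps allows, so there is no firm sign that the core alters the effect of this change: the same change on two cores in this assay, a 1.1-fold lower number (0.05 log units; within the scatter) from compound 1 to compound 3 and a 2.5-fold lower number (0.39 log units; beyond the scatter) from compound 2 to compound 4, 2.2-fold (0.34 log units) apart, within the scatter of two such steps This does not show that the change carries over unaltered, since two steps on two cores are few, only one of them lies beyond the scatter, and the entering fluoro has different surroundings in each case.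

The compounds shown leave open how the number would move with an amine, a nitrile or a carboxylic acid on the aromatic ring in place of fluoro. They also leave open whether the chloro and hydroxy groups, present in all four compounds, matter for this read-out.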